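Sulfonyl enones on DU-145: thienyl for methylsulfanylphenyl

A few compounds are considered here, and "the series" means these few. Any claim that something is new, unique, unknown or untested is made for them only; others in the source may bear on it.

Compound 2 `CSc1ccc(/C=C(\C(=O)c2ccc(Br)cc2)S(=O)(=O)c2ccc(C)cc2)cc1` is the reference point of this series; in a functional assay on DU-145 cells (Homo sapiens) for inhibition, read by trypan blue exclusion, with a stated time of 96 h (on this read-out higher numbers stand for weaker inhibition of growth and lower numbers for stronger inhibition of growth), compound 2 gives 1000 nM. Compound 1 `Cc1ccc(S(=O)(=O)/C(=C/c2ccc(C)s2)C(=O)c2ccc(Br)cc2)cc1` differs from it by 5-methylthiophen-2-yl in place of 4-(methylsulfanyl)phenyl on a double-bonded chain carbon bound to a double-bonded chain carbon and in this assay compound 1 gives 25000 nM, a step of a 25-fold higher number from compound 2 to compound 1 (1.40 log units; beyond the scatter). Compound 3 `CSc1ccc(/C=C(\C(=O)c2ccc(Cl)cc2)S(=O)(=O)Cc2ccc(Cl)cc2)cc1` carries a different core; the difference between the two cores is not broken down here. In this assay compound 3 gives 10000 nM. Compound 4 `Cc1ccc(/C=C(\C(=O)c2ccc(Cl)cc2)S(=O)(=O)Cc2ccc(Cl)cc2)s1` is not yet measured and differs from compound 3 by 5-methylthiophen-2-yl in place of 4-(methylsulfanyl)phenyl on a double-bonded chain carbon bound to a double-bonded chain carbon, the same change, at the same place, as between compound 2 and compound 1. Going by the values given here, the step from compound 3 to compound 4 is expected to be a 10-fold higher number from compound 3 to compound 4 (1.00 log units; beyond the scatter), resting on the single measured step of a 25-fold higher number from compound 2 to compound 1 (1.40 log units; beyond the scatter). Compound 4 is therefore expected to show about 100000 nM, between 30000 nM and 300000 nM.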

Compound 4, concentration for 50% growth inhibition: 1000 nM
For compound 4 the middle estimate is 100-fold (2.00 log units) above the measured one; measured number outside the range, below it.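

In this assay, 5-methylthiophen-2-yl in place of 4-(methylsulfanyl)phenyl gives a 10-fold lower number from compound 3 to compound 4 (1.00 log units; beyond the scatter). Set beside the earlier pair, the change does not carry over from one core to the other, not even in direction: the same change on two cores in this assay, a 25-fold higher number (1.40 log units; beyond the scatter) from compound 2 to compound 1 and a 10-fold lower number (1.00 log units; beyond the scatter) from compound 3 to compound 4, 250-fold (2.40 log units) apart, beyond the scatter of two such steps. The outcome of this change therefore depends on the core in these four compounds, but two pairs do not show which difference between the cores is responsible, nor do they give a rule for the wider series.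

Going by these compounds, it remains open how an unsubstituted thiophen-2-yl or a 4-(dimethylamino)phenyl group would behave at this place on each core. Either could follow the pair of compound 1 and compound 2, the pair of compound 3 and compound 4, or neither.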